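Adding Ethoxy to Compound 3

The source may hold more compounds than are shown below. What is called first, only, known or untested is meant among the compounds shown, and "the series" means these compounds.

Three compounds supply the starting data: compound 1 (`CCOc1cc(C)c(-c2cccc(CNc3ccc(OCC(=O)O)cc3)c2)c(C)c1`), compound 2 (`COCCOc1cc(C)c(-c2cccc(CNc3ccc(OCC(=O)O)c(F)c3)c2)c(C)c1`) and compound 3 (`Cc1ccccc1-c1cccc(CNc2ccc(OCC(=O)O)c(F)c2)c1`). In a physicochemical assay for lipophilicity, read by HPLC, in phosphate buffer, measured as octanol-water partition, at pH 7.4, tested at 100 uM (a lower number here means a more polar compound, a higher number a more lipophilic compound), compound 1 gives "not determined" (no result reported) and so offers nothing to compare. In this assay compound 2 reads 2.47 and compound 3 reads 2.41 and these two values lie within the usual scatter of each other. Among the measured compounds shown here, compound 3 thus stands level with compound 2 on the only two numbers available, and no pair of measured compounds differing in one place offers a guide.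

Compound 4 (`CCOc1ccc(-c2cccc(CNc3ccc(OCC(=O)O)c(F)c3)c2)c(C)c1`) comes from compound 3 by a single change (ethoxy in place of hydrogen on an aromatic carbon): ethoxy in place of hydrogen on an aromatic carbon, para to a large group and meta to a methyl group. The same difference reads 2-methylphenyl to 4-ethoxy-2-methylphenyl. In this assay, for the measured compounds named here, a modest upward step is expected, perhaps only just beyond the scatter, though no measured pair tests this. The expectation starts from compound 3 at 2.41 and rests on the structural change alone. The expected change is a number 0.34 log units higher from compound 3 to compound 4 (beyond the scatter) and remains an estimate. For compound 4 the estimated value is 2.75 with an expected range from 2.4 to 3.1 in this assay when it is measured.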

Compound 4, distribution coefficient: 2.83
The estimate for compound 4 lay 0.08 log units below the measured number; measured number inside the range.
By their numbers in this assay, from the lowest: compounds 3 and 2 (each within the scatter of the next); then compound 4.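

In this assay, among the compounds shown here, the exchange of hydrogen for ethoxy gives a number 0.42 log units higher from compound 3 to compound 4 (beyond the scatter), which is the first reading of a single change, since the earlier compounds offered no measured pair differing in one place. It shows that this position, on an aromatic carbon para to a large group and meta to a methyl group, is not silent in this measurement: adding ethoxy, with its 3 heavy atoms and no net charge, to the 2-methylphenyl group moves the number by more than repeat measurements would. Nothing available explains why the step has this size.

As far as these compounds go, the result rests on one pair and one substituent, so it remains open whether a longer chain such as butoxy, or an amine such as dimethylamino, at the same position would move the number further, less or the other way. Also open, from the compounds shown here alone, is whether ethoxy would give a step of similar size on another carbon of that ring or in a compound without the methyl group.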